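Compound 4: one trifluoromethyl fewer than compound 3

The source may report more compounds than this note shows. Statements on the series, on what has been measured and on what is new or still open speak of the compounds shown alone.

Measured in a functional assay on NCI-H23 cells (Homo sapiens) for inhibition, read by sulforhodamine B assay, with a stated time of 48 h, tested at 0.1 uM; a lower number here means a stronger effect, a higher number a weaker effect of the compound at the concentration tested:
compound 1 `O=C(Nc1cccc(-n2cc(-c3ccncc3)c(-c3cc(O)cc(Cl)c3)n2)c1)Nc1ccc(Cl)c(C(F)(F)F)c1` gives 91%
compound 2 `COc1cc(Cl)cc(-c2nn(-c3cccc(NC(=O)Nc4ccc(Cl)c(C(F)(F)F)c4)c3)cc2-c2ccncc2)c1` gives 90%
compound 3 `COc1cc(Cl)cc(-c2nn(-c3cccc(NC(=O)Nc4cc(C(F)(F)F)cc(C(F)(F)F)c4)c3)cc2-c2ccncc2)c1` gives 95%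

Compound 3 holds the largest of the three numbers, yet its gaps to compound 1 and to compound 2 both lie within the scatter. Among the compounds with values here, the only step with one change, a number 1 percentage points lower from compound 1 to compound 2 (within the scatter), touches another part of the molecule and is itself within the scatter. Compound 4 `COc1cc(Cl)cc(-c2nn(-c3cccc(NC(=O)Nc4cccc(C(F)(F)F)c4)c3)cc2-c2ccncc2)c1` differs from compound 3 by hydrogen in place of trifluoromethyl on an aromatic carbon, the remaining trifluoromethyl sitting meta to the vacated aromatic carbon. Within the data shown here, no measured step concerns this site, and the values of compound 2 and compound 3, which differ there, lie within the scatter of each other. No step beyond the scatter is therefore expected in this assay. Compound 4 is estimated at 90% (range 78% to 99%), an expected step of a number 5 percentage points lower from compound 3 to compound 4 (within the scatter).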

Compound 4, a percentage reported as activity, at one concentration (the size of the read-out at that concentration, not a potency): 90%
The estimate for compound 4 equals the measured number at the digits printed, and the stated range covers the measured number.
By their numbers in this assay, from the lowest: compounds 2, 4, 1 and 3 (each within the scatter of the next).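

In this assay hydrogen in place of trifluoromethyl gives a number 5 percentage points lower from compound 3 to compound 4 (within the scatter) on this aromatic carbon, and hydrogen in place of chloro gives no change at the digits printed from compound 2 to compound 4 (within the scatter) on the same ring. Neither replacement moves the read-out beyond the scatter at this single concentration, so this position shows no dependence on trifluoromethyl here. No measurement at hand bears on why this is so. Going by these compounds, whether an amine or a carboxylic acid on this aromatic carbon would leave the read-out equally unmoved remains open. So does the behaviour of these compounds at higher concentrations.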